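The compounds below may be only part of what the source reports. "The series", "measured", "known", "first", "only" and "open" are said of these compounds alone.

Measured compounds in a functional assay on MCF7 cells (Homo sapiens) for antiproliferative activity, read by trypan blue exclusion, with a stated time of 24 h; a higher number here means a weaker inhibitor, a lower number a stronger inhibitor:
compound 1 `O=C1NC(=O)/C(=C/c2cn(Cc3ccccc3)c3ccccc23)N1` gives 27300 nM
compound 2 `N#Cc1ccc(Cn2cc(/C=C3\NC(=O)NC3=O)c3ccccc32)cc1` gives 14100 nM
compound 3 `O=C1NC(=O)/C(=C/c2cn(Cc3ccc([N+](=O)[O-])cc3)c3ccccc23)N1` gives 10900 nM

Compound 1 stands highest of the three numbers in this assay. Its nearest neighbour is compound 2, with a step of a 1.9-fold lower number from compound 1 to compound 2 (0.29 log units; within the scatter), a gap that the usual scatter covers. The furthest is compound 3, at a 2.5-fold lower number from compound 1 to compound 3 (0.40 log units; beyond the scatter), a modest but real drop. Between compounds 2 and 3 the step is a 1.3-fold lower number from compound 2 to compound 3 (0.11 log units; within the scatter), so the two substituted compounds cannot be ordered against each other.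

Compound 4 `Cc1ccc(Cn2cc(/C=C3\NC(=O)NC3=O)c3ccccc32)cc1` differs from compound 1 by methyl in place of hydrogen on an aromatic carbon. Both measured steps from compound 1 place a group at the same aromatic carbon, and both lowered the number in this assay, one within the scatter and one just beyond it. Among the measured compounds shown here, no measured compound carries a methyl, so the only guide is that substitution at this place has so far given a small downward move. For compound 4 a step of similar or smaller size is therefore expected, downward or none beyond the scatter, namely a 1.4-fold lower number from compound 1 to compound 4 (0.14 log units; within the scatter). Compound 4 is estimated at 20000 nM in this assay, with a range of 10000 nM to 40000 nM.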

Compound 4, half-maximal inhibitory concentration: 20200 nM
Compound 4: middle estimate off by 1.0-fold (0.00 log units), on the low side, and the stated range covers the measured number.
By their numbers in this assay, from the lowest: compounds 3, 2, 4 and 1 (each within the scatter of the next, the first and the last beyond it).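

Going from benzyl to 4-methylbenzyl in this assay gives a 1.4-fold lower number from compound 1 to compound 4 (0.13 log units; within the scatter) and so does not separate methyl at this place from hydrogen, unlike nitro, the one group so far whose step from compound 1 is beyond the scatter. Methyl also cannot be separated from the other two groups, with a 1.4-fold higher number from compound 2 to compound 4 (0.16 log units; within the scatter) alongside a 1.9-fold higher number from compound 3 to compound 4 (0.27 log units; within the scatter) at the same carbon, so methyl, nitrile and nitro cannot be ordered here. No measurement available accounts for these numbers.

Still open, going by these compounds, is whether an amine or a carboxylic acid at this carbon would give a step clearly beyond the scatter from compound 1. Also open, on these data alone, is how a longer chain such as ethyl or butyl would compare with methyl here.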